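Fluoro to cyano: an unmeasured step on a shared core

The compounds below may be only part of what the source reports. "The series", "measured", "known", "first", "only" and "open" are said of these compounds alone.

Compound 1 `O=C(NNc1ccnc2cc(Cl)ccc12)c1ccccc1/N=C/c1ccc(F)cc1`: 5.18
Compound 2 `O=C(NNc1ccnc2cc(Cl)ccc12)c1ccccc1/N=C/c1ccc(Cl)c(Cl)c1`: 6.22
Compound 3 `O=C(NNc1ccnc2cc(Cl)ccc12)c1ccccc1/N=C/c1ccc(Br)cc1`: 5.76

In a physicochemical assay for lipophilicity, measured as octanol-water partition (on this read-out higher numbers stand for higher lipophilicity and lower numbers for lower lipophilicity), compound 1 stands lowest of the three. The nearest measured step is a number 0.58 log units higher from compound 1 to compound 3 (beyond the scatter), the furthest a number 1.04 log units higher from compound 1 to compound 2 (beyond the scatter), and between the other two a number 0.46 log units lower from compound 2 to compound 3 (beyond the scatter). Compound 4 `N#Cc1ccc(/C=N/c2ccccc2C(=O)NNc2ccnc3cc(Cl)ccc23)cc1` differs from compound 1 in one place: cyano in place of fluoro on an aromatic carbon. None of the three measured steps exchanges a halogen for a cyano group; all of them trade halogens among themselves, and each moved this assay beyond the scatter. They give no direct guide to the new group. For compound 4 a modest downward step is expected, a number 0.58 log units lower from compound 1 to compound 4 (beyond the scatter). The estimate for compound 4 in this assay is 4.6, with a range from 4.1 to 5.1.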

Compound 4, partition coefficient: 4.83
Beside the measured number, compound 4's estimate is 0.23 log units below it; measured number inside the range.
By their numbers in this assay, from the lowest: compound 4; then compound 1; then compound 3; then compound 2.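

Cyano in place of fluoro moved the number down (a number 0.35 log units lower from compound 1 to compound 4 (beyond the scatter)), the only downward step from compound 1 shown at this position. The drop is greater from the bromo compound (a number 0.93 log units lower from compound 3 to compound 4 (beyond the scatter)) and greatest from the 3,4-dichlorophenyl compound (a number 1.39 log units lower from compound 2 to compound 4 (beyond the scatter)). Compound 4 therefore stands lowest in this assay, and this position can carry the number below compound 1 as well as above it. Nothing measured here explains the shift. Where an amine or a carboxylic acid at this position would fall remains open.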